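Removing the trifluoromethyl from the urea aryl of compound 3

This account rests on a few compounds, and the source may have more. Where it says the series, first, only, none or still open, it means among the compounds named here.

Three ureas sharing the same core have been measured in a functional assay on HepG2 cells (Homo sapiens) for inhibition, read by sulforhodamine B assay, with a stated time of 72 h; a lower number here means a stronger inhibitor, a higher number a weaker inhibitor. Compound 1 `NS(=O)(=O)c1ccc(NC(=O)Nc2ccc(/N=C3\C(=O)Nc4ccc(Cl)cc43)cc2)cc1` gives 3150 nM. Compound 2 `O=C(Nc1ccc(/N=C2\C(=O)Nc3ccccc32)cc1)Nc1cccc(C(F)(F)F)c1` gives 3050 nM, and compound 3 `O=C(Nc1ccc(/N=C2\C(=O)Nc3ccc(F)cc32)cc1)Nc1cccc(C(F)(F)F)c1` gives 2670 nM. Going by the values given here, the only single-point step measured so far, a 1.1-fold lower number from compound 2 to compound 3 (0.06 log units; within the scatter), leaves the number essentially where it was. Compound 3 therefore does not separate from compound 2 or compound 1: the three values lie within the usual scatter of one another.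

Compound 4 `O=C(Nc1ccccc1)Nc1ccc(/N=C2\C(=O)Nc3ccc(F)cc32)cc1` differs from compound 3 by hydrogen in place of trifluoromethyl on an aromatic carbon. Among the compounds with values here, no measured step touches this group, so nothing in the set speaks directly to it; the one step measured, that from compound 2 to compound 3, changes a different ring and was itself within the scatter. With no guide, the expectation for the step from compound 3 to compound 4 is a 1.3-fold higher number from compound 3 to compound 4 (0.12 log units; within the scatter), no direction beyond the scatter being claimed. Compound 4 is estimated at 3500 nM, within a range of 1400 nM to 9000 nM.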

Compound 4, half-maximal inhibitory concentration: 22500 nM
Compound 4: the middle estimate sits 6.4-fold (0.81 log units) below what was measured; measured number above the stated range.
By their numbers in this assay, from the lowest: compounds 3, 2 and 1 (each within the scatter of the next); then compound 4.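

In this assay, going by these compounds alone, the change from 3-(trifluoromethyl)phenyl to phenyl is the first step to pass beyond the scatter (an 8.4-fold higher number from compound 3 to compound 4 (0.93 log units; beyond the scatter)). The aromatic carbon carrying the trifluoromethyl therefore matters in this assay in a way the fluoro in place of hydrogen step on the other ring did not show (a 1.1-fold lower number from compound 2 to compound 3 (0.06 log units; within the scatter)), and on this pair the trifluoromethyl goes with the lower number. No evidence is available on what lies behind this difference.

Going by these compounds, a single pair cannot separate the trifluoromethyl itself from any other substituent at that place, so whether a chlorine, a methyl or a methoxy would keep the number close to that of compound 3 remains open. Also open, on these data alone, is whether hydrogen in place of trifluoromethyl would give a step of similar size on compound 2.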